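Swapping an ester for a hydroxy amide on a shared core

The source may report more compounds than this note shows. Statements on the series, on what has been measured and on what is new or still open speak of the compounds shown alone.

Compound 1 `C#CCCOC(=O)c1ccc(C(CC)(CC)c2ccc(OCCC(O)(CC)CC)c(C)c2)n1CC` carries an ester group on a carbonyl carbon whose other neighbour is an aromatic carbon. In a functional assay on HepG2 cells (Homo sapiens) for antiproliferative activity, read by MTT assay, with a stated time of 48 h (a higher number here means a weaker inhibitor, a lower number a stronger inhibitor), compound 1 gives only a limit, > 50000 nM, rather than a number. Compound 2 `CCC(C)C(NC(=O)c1ccc(C(CC)(CC)c2ccc(OCCC(O)(CC)CC)c(C)c2)n1CC)C(=O)OC` and compound 3 `CCOC(=O)C(CC(=O)OC)NC(=O)c1ccc(C(CC)(CC)c2ccc(OCCC(O)(CC)CC)c(C)c2)n1CC` carry amides in place of that ester. In this assay compound 2 likewise reaches only the limit, > 50000 nM. For compound 3 this assay again reports a limit, > 50000 nM. Because (the limit of > 50000 nM in this assay, at which 3 of the 3 values shown sit), none of the steps among these three can be sized: a step that the two limits leave unreadable from compound 1 to compound 2, a step that the two limits leave unreadable from compound 1 to compound 3 and a step that the two limits leave unreadable from compound 2 to compound 3. Compound 4 `CCn1c(C(=O)NC(C)CO)ccc1C(CC)(CC)c1ccc(OCCC(O)(CC)CC)c(C)c1` has not yet been tested and differs from compound 1 in one place: (1-(hydroxymethyl)ethyl)amino in place of (but-3-yn-1-yl)oxy on a carbonyl carbon. The steps from compound 1 to compound 2 and to compound 3 also trade the ester for an amide at the same carbonyl carbon, so they bear most directly on this change, yet their size is unreadable. Within the data shown here, no measured step therefore points to a change in this assay, and the expected step that the limit leaves unreadable from compound 1 to compound 4 is a continuation of the limit. Compound 4 is estimated at 60000 nM, with a range from 20000 nM to 200000 nM, most likely reported as a limit once more.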

Compound 4, half-maximal inhibitory concentration: 43100 nM
Estimate against measurement, compound 4: 1.4-fold (0.14 log units) above, within the range that was stated.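

In this assay, among these compounds, compound 4 is the only one of the four compounds to give a number, 43100 nM, which shows that (1-(hydroxymethyl)ethyl)amino on this carbonyl carbon can yield a readable value in the assay. On these data alone, its steps are known only as floors: an at least 1.1-fold lower number from compound 1 to compound 4 (0.06 log units; that floor lies within the scatter), an at least 1.1-fold lower number from compound 2 to compound 4 (0.06 log units; that floor lies within the scatter) and an at least 1.1-fold lower number from compound 3 to compound 4 (0.06 log units; that floor lies within the scatter), so the result shows no change beyond the scatter, and the true size of each step remains unknown. The steps among compound 1, compound 2 and compound 3 still cannot be read, because of where their values sit: the limit of > 50000 nM in this assay, at which 3 of the 4 values shown sit.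

The compounds shown leave open whether the hydroxyl of the (1-(hydroxymethyl)ethyl)amino group matters, since a plain isopropylamino group on the same carbonyl carbon would be needed to separate the hydroxyl from the rest of the chain. Also open, as far as these compounds go, is what a carboxylic acid or a longer hydroxyalkyl amine would give at this carbonyl carbon, and whether any group here can bring the number in this assay clearly beyond the scatter from that of compound 4.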